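This account rests on a few compounds, and the source may have more. Where it says the series, first, only, none or still open, it means among the compounds named here.

Working notes on the series, measured in a functional assay on IGROV-1 cells (Homo sapiens) for inhibition, read by sulforhodamine B assay, with a stated time of 48 h; on this read-out higher numbers stand for lower toxicity in this test and lower numbers for higher toxicity in this test. Compound 1 `Nc1cc(N)c2nc(-c3ccccc3)c(NCc3ccc(Cl)c(Cl)c3)nc2c1` gives 29500 nM. Compound 3 `COc1ccc(CNc2nc3cc(N)cc(N)c3nc2-c2ccccc2)cc1` gives 56200 nM, so that the change from compound 1 to compound 3 is a 1.9-fold higher number from compound 1 to compound 3 (0.28 log units; within the scatter). For compound 2 `Nc1cc(N)c2nc(-c3ccccc3)c(NCc3ccc(F)cc3)nc2c1` the assay returned only a limit, < 100000 nM. Owing to the limit of < 100000 nM in this assay, at which 1 of the 3 values shown sits, the step that the limit leaves unreadable from compound 1 to compound 2 and the step that the limit leaves unreadable from compound 2 to compound 3 cannot be sized, and compound 2 can only be placed as no more potent than that limit allows. Compound 4 `Nc1cc(N)c2nc(-c3ccccc3)c(Sc3ccc(F)cc3)nc2c1` has not been measured in this assay; it differs from compound 2 by (4-fluorophenyl)sulfanyl in place of (4-fluorobenzyl)amino on an aromatic carbon. Going by the values given here, none of the measured steps covers this change, and every measured compound of the series sits at weak toxicity. Among the compounds with values here, the only guide is the band spanned by compound 1 and compound 3 and the limit of compound 2. Compound 4 is therefore expected at 50000 nM, with a range from 15000 nM to 100000 nM. The expected step is accordingly a step that the limit leaves unreadable from compound 2 to compound 4, which starts from a limit.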

Compound 4, concentration lethal to 50% of the cells: < 100000 nM
Compound 4 ended at the assay's limit; the forecaster's own chance of this, stated with the estimate: 35%; the middle value lies beyond the limit too.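

No step from compound 2 to compound 4 can be read in this assay, because each compound returned only a limit: the limit of < 100000 nM in this assay, at which 2 of the 4 values shown sit.

The compounds shown leave open how far (4-fluorophenyl)sulfanyl in place of (4-fluorobenzyl)amino on this aromatic carbon shifts the number, and in which direction.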